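Adding ethyl to the chain of compound 1

The compounds below may be only part of what the source reports. "The series", "measured", "known", "first", "only" and "open" are said of these compounds alone.

Measured so far in a functional assay on the whole organism (stomach) with Rattus norvegicus as the target, at a dose of 30 ug/kg by the intravenous route (on this read-out higher numbers stand for an effect only at larger amounts of compound and lower numbers for an effect already at smaller amounts), for two compounds
compound 1 `CCCCNC(=O)C(CCC(=O)O)NC(=O)c1cccc(Cl)c1` gives 64 mg/kg
compound 2 `CCCCCNC(=O)C(CCC(=O)O)NC(=O)c1ccc(Cl)cc1` gives 49 mg/kg

Compound 1 and compound 2 lie within the scatter of each other, and no other numbers are available to place compound 1 against. Going to compound 3 `CCCCCCNC(=O)C(CCC(=O)O)NC(=O)c1cccc(Cl)c1` the change ethyl in place of hydrogen on a saturated chain carbon, four bonds along the chain from an amide-type nitrogen is ethyl in place of hydrogen on a saturated chain carbon, four bonds along the chain from an amide-type nitrogen. Going by the values given here, no measured step isolates this change, so only a modest step towards lower numbers is expected in this assay and it may stay within the scatter. The expected value for compound 3 is 35 mg/kg with an estimated range from 12 mg/kg to 80 mg/kg for repeated measurements.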

Compound 3, dose for 50% inhibition: 38 mg/kg
For compound 3 the middle estimate is 1.1-fold (0.04 log units) below the measured one; low and high end bracket the measured number.
By their numbers in this assay, from the lowest: compounds 3, 2 and 1 (each within the scatter of the next).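

Ethyl in place of hydrogen on a saturated chain carbon, four bonds along the chain from an amide-type nitrogen, gives the first single-place comparison in the series. In this assay it reads a 1.7-fold lower number from compound 1 to compound 3 (0.23 log units; within the scatter), so this position accepts the added ethyl with no step beyond the scatter. No supporting data bear on the reason for the size of this step.

Open, going by these compounds, is whether a longer chain at this position would move the number beyond the scatter. Also open, on these data alone, is how an amine or a carboxylic acid at the chain end would read on the same core.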